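The compounds below may be only part of what the source reports. "The series", "measured", "known", "first", "only" and "open" are said of these compounds alone.

Compound 1 `CCn1cc(-c2nc3ccccc3[nH]2)c(=O)c2cc(F)c(N3CCNCC3)cc21`: > 10000 nM
Compound 2 `CCn1cc(-c2nc3ccc([N+](=O)[O-])cc3o2)c(=O)c2cc(F)c(N3CCNC(C)C3)c(F)c21`: 3900 nM

In a functional assay on Hep 3B2 cells (Homo sapiens) for cytotoxicity, read by sulforhodamine B assay, with a stated time of 48 h (a higher number here means a weaker inhibitor, a lower number a stronger inhibitor), compound 1 gives only a limit, > 10000 nM, and this value is one of those that sit at the limit of > 10000 nM in this assay, at which 1 of the 2 values shown sits. Compound 2, in this assay, gives 3900 nM. For the measured compounds named here, these two compounds differ in more than one place at once, so no single-change step between them is known, and their two values can only be set side by side. Compound 3 `CCn1cc(-c2nc3ccc(N)cc3[nH]2)c(=O)c2cc(F)c(N3CCNCC3)cc21` has not yet been measured in this assay; it differs from compound 1 by amino in place of hydrogen on an aromatic carbon, the amino entering on an aromatic carbon of the shared core of compound 1. Going by the values given here, with no measured step of this kind to rest on, the step in this assay from such an exchange is expected to be small, probably within the scatter, in either direction. Compound 3 is therefore expected to give about 12000 nM, between 4000 nM and 40000 nM, in this assay. The step this estimate means is a step that the limit leaves unreadable from compound 1 to compound 3.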

Compound 3, half-maximal inhibitory concentration: > 10000 nM
Compound 3 gave a limit, no number; the forecaster's own chance of this, stated with the estimate: 60%; the middle value does not contradict the limit.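

Compound 3 gives only a limit in this assay, > 10000 nM, and with compound 1 also at a limit, no step can be read between these two compounds: the limit of > 10000 nM in this assay, at which 2 of the 3 values shown sit.

The compounds shown leave open whether amino in place of hydrogen on an aromatic carbon changes the value in this assay at all.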